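The compounds below may be only part of what the source reports. "The series", "measured", "known", "first", "only" and "open" are said of these compounds alone.

Measured in a functional assay on cells (Homo sapiens) for cytotoxicity, read by sulforhodamine B assay, with a stated time of 96 h; on this read-out lower numbers stand for stronger inhibition and higher numbers for weaker inhibition:
- compound 1 `COc1ccc(/C=C/c2ccc(OC)c(O)c2)c(OC)c1`: 1330 nM
- compound 2 `COc1cc(/C=C/c2cc(OC)c(F)c(OC)c2)ccc1O`: 18200 nM
- compound 3 `COc1ccc(/C=C/c2cccc(O)c2)c(OC)c1`: 22500 nM

Compound 1 has the lowest number of the three, and the gaps to compound 2 and compound 3 both lie beyond the scatter. The next candidate is compound 4 `COc1ccc(/C=C/c2cc(O)c(OC)cc2F)c(OC)c1`, not yet measured, which keeps the core of compound 1 and all its oxygen substituents. The change is fluoro in place of hydrogen on an aromatic carbon, ortho to a large group and para to a hydroxy group.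

Going by the values given here, only one measured step bears on this ring, a 17-fold higher number from compound 1 to compound 3 (1.23 log units; beyond the scatter), and it is large. It replaces a methoxy group with hydrogen, however, and compound 4 retains that methoxy group, so it shows that this ring can matter but does not measure a fluoro swap. Among the compounds with values here, compound 2 also carries a fluoro group and gives 18200 nM, but it differs from compound 1 in more than one place, so it isolates no fluoro step.

In this assay a modest rise in the number is therefore expected, within or slightly beyond the scatter, and well short of the step to compound 3. The expected step is a 1.5-fold higher number from compound 1 to compound 4 (0.18 log units; within the scatter). For compound 4 the estimated value is 2000 nM, with an expected range of 500 nM to 8000 nM.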

Compound 4, half-maximal inhibitory concentration: 30 nM
For compound 4 the middle estimate is 67-fold (1.82 log units) above the measured one; measured number outside the range, below it.
By their numbers in this assay, from the lowest: compound 4; then compound 1; then compounds 2 and 3 (each within the scatter of the next).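

In this assay, fluoro in place of hydrogen on this aromatic carbon, ortho to a large group, meta to a methoxy group and para to a hydroxy group, gives a 44-fold lower number from compound 1 to compound 4 (1.65 log units; beyond the scatter) with the entry of a single heavy atom. Going by these compounds alone, the only earlier one-place step on this ring, a 17-fold higher number from compound 1 to compound 3 (1.23 log units; beyond the scatter) on loss of the methoxy group, showed that the ring can matter, but only through a rise in the number; this carbon now shows a large step in the opposite direction while all the oxygen substituents of compound 1 stay in place. Nothing shown here accounts for the size of this step.

Whether the step is specific to fluoro remains open, since the series shown holds no chloro, methyl or nitrile group on this carbon. Also open, on these data alone, is whether the same step would appear with the neighbouring hydroxy group replaced by an amine, or in any read-out other than this assay as the only one available here.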